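The compounds below may be only part of what the source reports. "The series", "measured", "known", "first", "only" and "open" are said of these compounds alone.

Compound 1 `COc1cc(-c2cc(/C=C/C(=O)c3ccc(N)cc3)[nH]n2)cc(OC)c1OC`: in a functional assay on SR cells (Homo sapiens) for cytotoxicity, read by sulforhodamine B assay, with a stated time of 48 h, tested at 100 uM (a higher number here means a weaker effect of the compound at the concentration tested, a lower number a stronger effect), compound 1 gives -13%.
Compound 2 `COc1ccc(C(=O)/C=C/c2cc(-c3cc(OC)c(OC)c(OC)c3)n[nH]2)cc1OC`: compound 2 gives 3%.
Compound 3 `COc1ccc(C(=O)/C=C/c2cc(-c3cc(OC)c(OC)c(OC)c3)n[nH]2)cc1`: compound 3 gives -5%.

All three numbers sit close to zero, so none of these compounds shows a clear effect at the concentration tested. Compound 3 stands second highest of the three; its gap to compound 1 and its gap to compound 2 are each within the usual scatter. Compound 4 `COc1cc(-c2cc(/C=C/C(=O)c3ccc(F)c(F)c3)[nH]n2)cc(OC)c1OC` differs from compound 3 by 3,4-difluorophenyl in place of 4-methoxyphenyl on a carbonyl carbon. Within the data shown here, the steps that bear on a change at this carbonyl carbon are a number 16 percentage points higher from compound 1 to compound 2 (beyond the scatter), a number 8 percentage points lower from compound 2 to compound 3 (within the scatter) and a number 8 percentage points higher from compound 1 to compound 3 (within the scatter); only the first lies beyond the scatter, and even that one is modest. A step of no size beyond the scatter is therefore expected, a number 5 percentage points higher from compound 3 to compound 4 (within the scatter). Compound 4 is estimated at 0%, in the range -15% to 15%.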

Compound 4, a percentage reported as activity, at one concentration (the size of the read-out at that concentration, not a potency): 8%
Compound 4: middle estimate off by 8 percentage points, on the low side; low and high end bracket the measured number.
By their numbers in this assay, from the lowest: compounds 1, 3, 2 and 4 (each within the scatter of the next, the first and the last beyond it).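

At this carbonyl carbon, the 3,4-difluorophenyl group gives a shift beyond the scatter against two of the earlier groups: a number 13 percentage points higher from compound 3 to compound 4 (beyond the scatter) and a number 21 percentage points higher from compound 1 to compound 4 (beyond the scatter) in this assay. Against 3,4-dimethoxyphenyl, it gives a number 5 percentage points higher from compound 2 to compound 4 (within the scatter), so those two groups cannot be told apart. The change at this position therefore moves the number only modestly, and all four compounds stay close to zero.

On these data alone, whether a carboxylic acid or an amide on this ring would give a clear effect stays open. No measurement given here accounts for these shifts.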